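Thiourea series: aryl to propyl step on the terminal nitrogen

This account rests on a few compounds, and the source may have more. Where it says the series, first, only, none or still open, it means among the compounds named here.

Values so far in a functional assay on the whole organism (strain Swiss albino) with Mus musculus as the target, in the maximal electroshock model, with a stated time of 0.5 h; on this read-out lower numbers stand for an effect already at smaller amounts and higher numbers for an effect only at larger amounts of compound:
- compound 1 `COc1cc2c(cc1OC)C(=O)C(CC1CCN(C(=S)Nc3ccccc3)CC1)C2`: 100 mg/kg
- compound 2 `COc1cc2c(cc1OC)C(=O)C(CC1CCN(C(=S)Nc3ccc(C)cc3)CC1)C2`: 30 mg/kg
- compound 3 `COc1cc2c(cc1OC)C(=O)C(CC1CCN(C(=S)Nc3ccc([N+](=O)[O-])cc3)CC1)C2`: 30 mg/kg

Compound 3 sits level with compound 2 at the digits recorded, and the two together hold the lowest numbers of the three; compound 1 is the furthest from compound 3, with a higher number (see a 3.3-fold lower number from compound 1 to compound 3 (0.52 log units; beyond the scatter)). The steps on the aromatic ring were both modest: a 3.3-fold lower number from compound 1 to compound 2 (0.52 log units; beyond the scatter) and a 3.3-fold lower number from compound 1 to compound 3 (0.52 log units; beyond the scatter), while no change at the digits printed from compound 2 to compound 3 (within the scatter).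

Compound 4 `CCCNC(=S)N1CCC(CC2Cc3cc(OC)c(OC)cc3C2=O)CC1` differs from compound 3 by propyl in place of 4-nitrophenyl on an amide-type nitrogen. Among the compounds with values here, none of the measured steps touches this kind of change: all three concern substitution on the aromatic ring, which is itself removed here. Within the data shown here, what the series does show is that the bare phenyl of compound 1 gave the highest number and that either substituent on that ring lowered it; no measured compound carries an alkyl group on the amide-type nitrogen. In this assay the expectation for compound 4 is therefore a step back toward the number of compound 1 rather than below compound 3, estimated as a 3.3-fold higher number from compound 3 to compound 4 (0.52 log units; beyond the scatter), with wide uncertainty. Compound 4 is accordingly estimated at 100 mg/kg, with a range of 30 mg/kg to 300 mg/kg.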

Compound 4, minimum effective dose: 100 mg/kg
Beside the measured number, compound 4's estimate shows no gap at the digits printed, within the range that was stated.
By their numbers in this assay, from the lowest: compounds 2 and 3 (each within the scatter of the next); then compounds 1 and 4 (each within the scatter of the next).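

In this assay the aromatic ring on the amide-type nitrogen can be exchanged for propyl without a readable loss when the ring is bare: the step gives no change at the digits printed from compound 1 to compound 4 (within the scatter) and the two groups cannot be told apart here. Against the substituted rings the same exchange is not neutral, with a 3.3-fold higher number from compound 3 to compound 4 (0.52 log units; beyond the scatter) for the loss of 4-nitrophenyl and a 3.3-fold higher number from compound 2 to compound 4 (0.52 log units; beyond the scatter) for the loss of 4-methylphenyl as the comparison. Across these four compounds the lower numbers therefore go with a substituted aromatic ring and not with an aromatic ring as such, compound 1 being the case against the ring alone, and no supporting data are available to account for these steps.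

On these data alone, whether a longer chain such as hexyl, a cyclohexyl ring or a benzyl group on the amide-type nitrogen stays with the propyl number or reaches the numbers of the substituted rings remains open. Also open, as far as these compounds go, is whether other ring substituents, such as methoxy or chloro, lower the number as methyl and nitro do.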